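Swapping the aryl group on the triazole nitrogen

The compounds below may be only part of what the source reports. "The series", "measured", "known", "first", "only" and "open" are said of these compounds alone.

Compound 1 `Cc1ccc(-n2cc(-c3ccccc3NS(=O)(=O)c3c[nH]c(=O)[nH]c3=O)nn2)cc1` and compound 2 `O=c1[nH]cc(S(=O)(=O)Nc2ccccc2-c2cn(-c3ccccc3F)nn2)c(=O)[nH]1` share one core. In a functional assay on OVCAR-3 cells (Homo sapiens) for antiproliferative activity, read by MTT assay, with a stated time of 24 h (on this read-out higher numbers stand for weaker inhibition and lower numbers for stronger inhibition), compound 1 gives 2190 nM, while compound 2 gives 15300 nM. The change between them, (2-fluorophenyl in place of 4-methylphenyl on an aromatic nitrogen), produced a 7.0-fold higher number from compound 1 to compound 2 (0.84 log units; beyond the scatter). Compound 3 `Cc1ccc(-n2cc(-c3cccc(NS(=O)(=O)c4c[nH]c(=O)[nH]c4=O)c3)nn2)cc1` has the same atoms as compound 1 joined differently; the difference between the two cores is not broken down here. In this assay compound 3 gives 3540 nM, which lies within the scatter of compound 1. Compound 4 `O=c1[nH]cc(S(=O)(=O)Nc2cccc(-c3cn(-c4ccccc4F)nn3)c2)c(=O)[nH]1` is not yet measured; it differs from compound 3 by 2-fluorophenyl in place of 4-methylphenyl on an aromatic nitrogen, the same change seen between compound 1 and compound 2. Because the earlier step was a 7.0-fold higher number from compound 1 to compound 2 (0.84 log units; beyond the scatter), compound 4 is expected to show roughly a 6.2-fold higher number from compound 3 to compound 4 (0.79 log units; beyond the scatter), resting on that single precedent. The estimate for compound 4 is 22000 nM, expected between 8000 nM and 60000 nM.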

Compound 4, half-maximal inhibitory concentration: 12500 nM
Estimate against measurement, compound 4: 1.8-fold (0.25 log units) above; the measured number falls inside the stated range.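

In this assay the replacement of 4-methylphenyl by 2-fluorophenyl on the aromatic nitrogen gives a 3.5-fold higher number from compound 3 to compound 4 (0.55 log units; beyond the scatter) and so weakens inhibition on this core as well. The change therefore carries over in direction, and the two steps cannot be told apart in size: the same change on two cores in this assay, a 7.0-fold higher number (0.84 log units; beyond the scatter) from compound 1 to compound 2 and a 3.5-fold higher number (0.55 log units; beyond the scatter) from compound 3 to compound 4, 2.0-fold (0.30 log units) apart, within the scatter of two such steps. This rests on only these two pairs of compounds, and it does not show why the number rises, or whether the loss of the methyl or the arrival of the fluorine accounts for the step.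

Going by these compounds, it remains open how a plain phenyl group would behave on that nitrogen, and whether an aryl group bearing an amine or a carboxylic acid would follow the same course on both cores.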